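The source may report more compounds than this note shows. Statements on the series, on what has been measured and on what is new or still open speak of the compounds shown alone.

In a functional assay on NCI-H727 cells (Homo sapiens) for antiproliferative activity, with a stated time of 48 h (on this read-out higher numbers stand for weaker inhibition and lower numbers for stronger inhibition), compound 1 `CCN(CC)c1ccc(-c2ccc(C(=O)OC)cc2)nn1` gives 90 nM. Compound 2 `CCOC(=O)c1ccc(-c2ccc(N(C)C)nn2)cc1` gives > 25000 nM, which is a limit of this assay and not a number. Compound 2 therefore stands at the limit of > 25000 nM in this assay, at which 1 of the 2 values shown sits, so its true potency is not known.

Compound 3 `COC(=O)c1ccc(-c2ccc(N(C)C)nn2)cc1` differs from compound 2 at a single place in the ester: hydrogen in place of methyl on a saturated chain carbon bound to an oxygen next to a carbonyl group. This is hydrogen in place of methyl on a saturated chain carbon bound to an oxygen next to a carbonyl group, and it turns ethoxycarbonyl to methoxycarbonyl. Compound 1 also carries methoxycarbonyl, but it differs from compound 3 elsewhere on the shared core. For the measured compounds named here, no measured pair isolates this change, so any forecast is loose.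

The methoxycarbonyl of compound 1, at 90 nM, is the only hint, and it points to a moderate or large step toward stronger inhibition in this assay. Compound 3 could still stay at the limit. The expected change is an at least 8.3-fold lower number from compound 2 to compound 3 (0.92 log units; beyond the scatter). For compound 3 the estimated value is 3000 nM, with an expected range from 200 nM to 25000 nM.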

Compound 3, half-maximal inhibitory concentration: > 25000 nM
Compound 3 gave a limit, no number (the forecaster's own chance of this, stated with the estimate: 35%); middle value at least 8.3-fold (0.92 log units) away from the limit.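

Shortening the ester from ethoxycarbonyl to methoxycarbonyl does not by itself bring a measurable effect in this assay: compound 3 gives > 25000 nM, which is a limit of the assay and not a number. Compound 2 also sits at a limit, so the step between these two compounds cannot be read and the ester change could be anything from no effect to a real one that stays hidden: the limit of > 25000 nM in this assay, at which 2 of the 3 values shown sit. Compound 3 does provide a new single-place comparison, since with methoxycarbonyl held constant, dimethylamino in place of diethylamino gives an at least 270-fold higher number from compound 1 to compound 3 (2.44 log units; beyond the scatter), which places a large readable difference at the amino group rather than at the ester.

On these data alone, the true potencies of compound 2 and compound 3 remain unknown, and so does the effect of the ester change in a compound that keeps diethylamino, where a value would fall within the range of the assay. As far as these compounds go, it also remains open whether a longer chain on the amine, such as dipropylamino, or a carboxylic acid in place of the ester would retain the activity of compound 1.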